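Trifluoromethyl for Nitro on Two Chalcone Cores

This account rests on a few compounds, and the source may have more. Where it says the series, first, only, none or still open, it means among the compounds named here.

Measured compounds:
compound 1 `COc1cc(O)cc(O)c1C(=O)/C=C/c1ccc([N+](=O)[O-])cc1` gives 41000 nM in a functional assay on HepG2 cells (Homo sapiens) for inhibition, read by MTT assay, with a stated time of 72 h; a lower number here means a stronger inhibitor, a higher number a weaker inhibitor
compound 2 `COc1cc(O)cc(O)c1C(=O)/C=C/c1ccc(C(F)(F)F)cc1` gives 14100 nM in this assay
compound 3 `COc1cc(OC)c(C(=O)/C=C/c2ccc([N+](=O)[O-])cc2)c(OC)c1` gives 9400 nM in this assay

Compound 2 differs from compound 1 by trifluoromethyl in place of nitro on an aromatic carbon, a change that brought a 2.9-fold lower number from compound 1 to compound 2 (0.46 log units; beyond the scatter). Compound 3 carries a different core; the difference between the two cores is not broken down here. Compound 4 `COc1cc(OC)c(C(=O)/C=C/c2ccc(C(F)(F)F)cc2)c(OC)c1` has not been measured; it differs from compound 3 by trifluoromethyl in place of nitro on an aromatic carbon, at the same place as before, so this is the same change made on the other core. Compound 3 and compound 2 lie within the scatter of each other, while compound 1 sits beyond both. The step from compound 3 to compound 4 is expected to be a 2.7-fold lower number from compound 3 to compound 4 (0.43 log units; beyond the scatter), resting on what the same change gave from compound 1 to compound 2. Compound 4 is therefore expected to give about 3500 nM, between 1500 nM and 9000 nM.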

Compound 4, half-maximal inhibitory concentration: 9700 nM
Compound 4: the middle estimate sits 2.8-fold (0.44 log units) below what was measured; measured number above the stated range.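

On the core of compound 3, trifluoromethyl in place of nitro gave a 1.0-fold higher number from compound 3 to compound 4 (0.01 log units; within the scatter), so the two groups cannot be told apart on this core. The change therefore did not carry over from one core to the other in this assay: the same change on two cores in this assay, a 2.9-fold lower number (0.46 log units; beyond the scatter) from compound 1 to compound 2 and a 1.0-fold higher number (0.01 log units; within the scatter) from compound 3 to compound 4, 3.0-fold (0.48 log units) apart, beyond the scatter of two such steps

This rests on a single pair on each core, so it does not show why the cores differ or whether other changes would also depend on the core. Still open, on these data alone, is how an amine, a carboxylic acid or a chlorine on the same aromatic carbon would behave on each core. Also open, as far as these compounds go, is which of the differences between the two cores governs the outcome.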